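Ester of the hydroxymethyl compound: expected inhibition

The source may report more compounds than this note shows. Statements on the series, on what has been measured and on what is new or still open speak of the compounds shown alone.

In a functional assay on the whole organism with Rattus norvegicus as the target, with a stated time of 4 h, at a dose of 40 mg/kg by the intraperitoneal route (on this read-out lower numbers stand for less inhibition and higher numbers for more inhibition at the one dose given (going by the name of the read-out)), compound 2 `Cc1nc2c(OCc3ccccc3)cccn2c1CO` gives 99%. Compound 3 `Cc1nc2c(OCc3ccccc3)cccn2c1Cl` gives 93% in this assay, a difference within the usual scatter, whereas compound 1 `Cc1nc2c(OCc3ccccc3)cccn2c1C(N)=O` gives 42%, well apart. The measured steps of a number 57 percentage points higher from compound 1 to compound 2 (beyond the scatter) and a number 51 percentage points higher from compound 1 to compound 3 (beyond the scatter) are both large; the step of a number 6 percentage points lower from compound 2 to compound 3 (within the scatter) is not. Compound 4 `Cc1nc2c(OCc3ccccc3)cccn2c1COC(=O)c1cccnc1` differs from compound 2 by (pyridin-3-yl)carbonyl in place of hydrogen on an oxygen on a saturated carbon: the hydroxy becomes ((pyridin-3-yl)carbonyl)oxy. Among the compounds with values here, no measured step alters this oxygen; the only one touching the hydroxymethyl group, from compound 2 to compound 3, stayed within the scatter. The step of a number 14 percentage points lower from compound 2 to compound 4 (beyond the scatter) is therefore expected to be none beyond the scatter, or a modest fall. Compound 4 is expected to give 85%, estimated between 55% and 100%.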

Compound 4, a percentage reported as inhibition, in the whole organism at one dose (the size of the read-out at that dose, not a potency): 87%
Estimate against measurement, compound 4: 2 percentage points below; low and high end bracket the measured number.
By their numbers in this assay, from the lowest: compound 1; then compounds 4, 3 and 2 (each within the scatter of the next, the first and the last beyond it).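

Replacing the hydrogen on this oxygen is the first change shown at the oxygen itself: in this assay the hydroxy to ((pyridin-3-yl)carbonyl)oxy change gives a number 12 percentage points lower from compound 2 to compound 4 (beyond the scatter) as a modest loss. A free hydroxy is thus not needed for most of the inhibition at this one dose, though the change is not neutral. Nothing available explains the size of this step.

Still open, as far as these compounds go, is whether an acetyl or benzoyl group on the same oxygen would give a step of similar size. An amine in place of the hydroxy also remains to be compared.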